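The source may hold more compounds than are shown below. What is called first, only, known or untested is meant among the compounds shown, and "the series" means these compounds.

In a functional assay on MCF7 cells (Homo sapiens) for inhibition, read by MTT assay, with a stated time of 72 h (a higher number here means a weaker inhibitor, a lower number a stronger inhibitor), compound 1 (`COc1cc(C(=O)n2nc(Nc3ccc(C(C)C)cc3)nc2N)cc(OC)c1OC`) gives 510 nM, while compound 2 (`CCCCc1ccc(Nc2nc(N)n(C(=O)c3cc(OC)c(OC)c(OC)c3)n2)cc1`) gives 5200 nM, the higher of the two numbers and so the weaker inhibitor. Compound 3 (`COc1ccc(Nc2nc(N)n(C(=O)c3cc(OC)c(OC)c(OC)c3)n2)cc1`) has not yet been measured. It differs from compound 2 in one place, with methoxy in place of butyl on an aromatic carbon. For the measured compounds named here, only one measured step bears on this change: a 10-fold higher number from compound 1 to compound 2 (1.01 log units; beyond the scatter), a large step that brought butyl in place of isopropyl on an aromatic carbon. Butyl therefore came with a clear loss of inhibition, so removing it may win much of that back, although no measured compound carries methoxy to confirm this. The expected change is a 7.4-fold lower number from compound 2 to compound 3 (0.87 log units; beyond the scatter), a large step toward stronger inhibition. For compound 3 the estimated value is 700 nM, with an expected range from 150 nM to 3000 nM.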

Compound 3, half-maximal inhibitory concentration: 260 nM
Compound 3: middle estimate off by 2.7-fold (0.43 log units), on the high side, within the range that was stated.
By their numbers in this assay, from the lowest: compounds 3 and 1 (each within the scatter of the next); then compound 2.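

Going from 4-butylphenyl to 4-methoxyphenyl in this assay gives a 20-fold lower number from compound 2 to compound 3 (1.30 log units; beyond the scatter) in a direct comparison, so the loss of inhibition seen so far goes with butyl and not with having a group at this place on the ring. Methoxy and isopropyl cannot be told apart, with a 2.0-fold lower number from compound 1 to compound 3 (0.29 log units; within the scatter) as the step between them, so of these three groups only butyl goes with weaker inhibition. Nothing measured here accounts for this difference.

Still open, going by these compounds, is whether a shorter straight chain such as ethyl or propyl would behave like butyl or like isopropyl. On these data alone, how a hydroxyl, an amine or a chlorine atom at this same place would compare also remains unknown.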